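Rearranging the Side Chain of Compound 1

A few compounds are considered here, and "the series" means these few. Any claim that something is new, unique, unknown or untested is made for them only; others in the source may bear on it.

Going by the values given here, only two compounds have been measured so far. In a functional assay (lung) for inhibition, with Cavia porcellus as the target (a higher number here means a weaker inhibitor, a lower number a stronger inhibitor), compound 1 (`CC(CCc1cccc(OCc2ccc3ccccc3n2)c1)Cc1nnn[nH]1`) gives 45 nM, the higher and therefore weaker of the two numbers. Compound 2 (`c1ccc2nc(COc3ccc(CC4CCCC4Cc4nnn[nH]4)cc3)ccc2c1`) gives 20 nM, and that gap lies beyond the usual scatter of repeated measurements.

The next compound to test is compound 3 (`CC(CCc1nnn[nH]1)Cc1cccc(OCc2ccc3ccccc3n2)c1`), which has the same atoms as compound 1, joined differently. On a saturated chain carbon bound to an aromatic carbon, 3-(1H-tetrazol-5-yl)-1-methylpropyl replaces 2-((1H-tetrazol-5-yl)methyl)propyl: 3-(1H-tetrazol-5-yl)-1-methylpropyl in place of 2-((1H-tetrazol-5-yl)methyl)propyl on a saturated chain carbon bound to an aromatic carbon. Nothing is added or lost, and the count of hydrogen-bond donors and acceptors stays the same.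

Among the compounds with values here, no measured pair of compounds shows what a rearrangement like this does, so any forecast is uncertain. A small move toward a higher number in this assay seems most likely, and it may well stay within the scatter. The expected change is a 1.3-fold higher number from compound 1 to compound 3 (0.12 log units; within the scatter). For compound 3, the estimated value is 60 nM, with an expected range from 15 nM to 240 nM.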

Compound 3, half-maximal inhibitory concentration: 150 nM
Beside the measured number, compound 3's estimate is 2.5-fold (0.40 log units) below it; measured number inside the range.
By their numbers in this assay, from the lowest: compound 2; then compound 1; then compound 3.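

Moving from 2-((1H-tetrazol-5-yl)methyl)propyl to 3-(1H-tetrazol-5-yl)-1-methylpropyl on a saturated chain carbon bound to an aromatic carbon brings a 3.3-fold higher number from compound 1 to compound 3 (0.52 log units; beyond the scatter) in this assay, which makes compound 3 the weaker inhibitor of the pair. The two side chains have the same heavy atoms and the same counts of hydrogen-bond donors and acceptors, so this step shows that the result at this position depends on how those atoms are joined, and not only on which atoms are present. Nothing measured here explains why this rearrangement raises the number.

This single step cannot separate the new place of the methyl group from the new place of the 1H-tetrazol-5-yl group, since both differ between the two side chains. It also leaves open how the number in this assay would respond to a longer chain at this position, or to a carboxylic acid in place of the 1H-tetrazol-5-yl group on either side chain.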